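The source may report more compounds than this note shows. Statements on the series, on what has been measured and on what is new or still open speak of the compounds shown alone.

Measured so far:

Compound 1, `CN(CCCc1ccccc1)Cc1cn(CC(O)COC(=O)c2ccccc2)nn1`, with 12%
Compound 2, `CCCCCCCC(=O)OCC(O)Cn1cc(CN(CCCC)CCCC)nn1`, with 71%
Compound 3, `CCCCN(CCCC)Cc1cn(CC(O)COC(=O)c2ccccc2)nn1`, with 12%

The three measured compounds were tested in an assay on nucleic acid for inhibition of Nucleic Acid, read by fluorescence, tested at 100 uM; on this read-out lower numbers stand for less inhibition and higher numbers for more inhibition at the one concentration tested (going by the name of the read-out). Compound 2 gives 71%, while compound 3 gives 12%. The two differ in one place only, (heptyl in place of phenyl on a carbonyl carbon), and this change brings a number 59 percentage points higher from compound 3 to compound 2 (beyond the scatter). Compound 1 gives 12%, level with compound 3 at the digits recorded, so the two sit together at the lower end of the three numbers, and their gap to compound 2 lies well beyond the scatter. How the core of compound 1 differs from the core of compound 3 is not broken down here.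

Compound 4, `CCCCCCCC(=O)OCC(O)Cn1cc(CN(C)CCCc2ccccc2)nn1`, is not yet measured in this assay. It is related to compound 1 by heptyl in place of phenyl on a carbonyl carbon, the same change that turned compound 3 into compound 2, made at the same place. Because compound 1 starts from 12%, the same starting level as compound 3, and because the earlier step was a number 59 percentage points higher from compound 3 to compound 2 (beyond the scatter), compound 4 is expected to rise by a comparable step, a number 53 percentage points higher from compound 1 to compound 4 (beyond the scatter). For the measured compounds named here, there is only one earlier instance of this change, so the expectation carries a wide margin. Compound 4 is therefore estimated at 65% in this assay, with a range from 40% to 85%.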

Compound 4, a percentage reported as inhibition, at one concentration (the size of the read-out at that concentration, not a potency): 12%
For compound 4 the middle estimate is 53 percentage points above the measured one, and the stated range ends above it.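

In this assay, heptyl in place of phenyl on a carbonyl carbon brings no change at the digits printed from compound 1 to compound 4 (within the scatter), so the rise seen on the core of compound 3 does not reappear on the core of compound 1. In this series, then, the size of this step cannot be carried from one core to another, and the two pairs disagree well beyond what repeated measurement would explain: the same change on two cores in this assay, a number 59 percentage points higher (beyond the scatter) from compound 3 to compound 2 and no change at the digits printed (within the scatter) from compound 1 to compound 4, 59 percentage points apart, beyond the scatter of two such steps. For the compounds shown here, what this does not show is which feature of the two cores decides the outcome, or why the change matters on one core and not on the other, and with only two pairs it gives no general rule for which cores respond.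

The compounds shown leave open how a shorter alkyl chain, a longer chain or a cyclohexyl group on the same carbonyl carbon would behave on either core, and so whether the high value of compound 2 is specific to heptyl. They also leave open whether a third amine, such as a piperidine or a dipropylamine in the core, would follow compound 2 or compound 4 when it carries the heptyl ester.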